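The source may report more compounds than this note shows. Statements on the series, on what has been measured and on what is new or still open speak of the compounds shown alone.

Compound 1 `O=C(/C=C/c1ccc(O)c(O)c1)N1CCN(c2cccc(Cl)c2)CC1` gives 1.29 ug/mL
Compound 2 `COc1ccc(N2CCN(C(=O)/C=C/c3ccc(O)c(O)c3)CC2)cc1` gives 0.93 ug/mL
Compound 3 `O=C(/C=C/c1ccc(O)c(O)c1)N1CCN(c2ccc([N+](=O)[O-])cc2)CC1` gives 1.56 ug/mL

In a functional assay on A549 cells (Homo sapiens) for antiproliferative activity, read by MTT assay, with a stated time of 48 h (on this read-out higher numbers stand for weaker inhibition and lower numbers for stronger inhibition), compound 3 stands level with the other two compounds, since a 1.2-fold higher number from compound 1 to compound 3 (0.08 log units; within the scatter) and a 1.7-fold higher number from compound 2 to compound 3 (0.22 log units; within the scatter) both stay within the scatter. Compound 4 `O=C(/C=C/c1ccc(O)c(O)c1)N1CCN(c2ccc(Cl)c(Cl)c2)CC1` differs from compound 3 by 3,4-dichlorophenyl in place of 4-nitrophenyl on an amine nitrogen in a ring in one place: 3,4-dichlorophenyl in place of 4-nitrophenyl on an amine nitrogen in a ring. These two steps and a 1.4-fold lower number from compound 1 to compound 2 (0.14 log units; within the scatter) all change the group at this place, and none of them leaves the scatter. No step beyond the scatter is therefore expected in this assay, and no firm direction. The expected move is a 1.3-fold lower number from compound 3 to compound 4 (0.11 log units; within the scatter) and it remains within the scatter. For compound 4 the estimated value is 1.2 ug/mL with an expected range from 0.6 ug/mL to 2.4 ug/mL in this assay.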

Compound 4, half-maximal inhibitory concentration: 1.74 ug/mL
For compound 4 the middle estimate is 1.5-fold (0.16 log units) below the measured one; low and high end bracket the measured number.
By their numbers in this assay, from the lowest: compounds 2, 1, 3 and 4 (each within the scatter of the next).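

Within this assay the 3,4-dichlorophenyl group on the amine nitrogen gives a 1.1-fold higher number from compound 3 to compound 4 (0.05 log units; within the scatter) and a 1.9-fold higher number from compound 2 to compound 4 (0.27 log units; within the scatter) and so adds a fourth aryl group that stands level with the others. Chloro in place of hydrogen on an aromatic carbon gives a 1.3-fold higher number from compound 1 to compound 4 (0.13 log units; within the scatter) and also stays within the scatter, so a second chloro does not separate compound 4 from compound 1. No measurement here bears on this level picture. The compounds shown leave open whether a carboxylic acid on the phenyl ring, or a benzyl group on the ring nitrogen, would move the number beyond the scatter.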